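Chain length and a methyl group: compound 4 against its neighbours

The compounds below may be only part of what the source reports. "The series", "measured", "known", "first", "only" and "open" are said of these compounds alone.

Measured so far:
compound 1, `Cc1ccc(NC(=O)CCCCc2cn(Cc3ccc4oc(-c5ccc(Cl)cc5)cc(=O)c4c3)nn2)cc1`, 32900 nM
compound 2, `O=C(CCCCc1cn(Cc2ccc3oc(-c4ccccc4)cc(=O)c3c2)nn1)Nc1ccc(F)cc1`, 15600 nM
compound 3, `O=C(CCc1cn(Cc2ccc3oc(-c4ccccc4)cc(=O)c3c2)nn1)Nc1ccccc1`, 15600 nM

In an assay on isolated protein for inhibition of Amine oxidase [flavin-containing] B (Homo sapiens), read by fluorescence and spectrophotometry (a lower number here means a stronger inhibitor, a higher number a weaker inhibitor), compound 3 stands level with compound 2 at the digits shown, and the two together give the lowest numbers of the three; compound 1 sits somewhat higher. Compound 4 is `Cc1ccc(NC(=O)CCCCc2cn(Cc3ccc4oc(-c5ccccc5)cc(=O)c4c3)nn2)cc1`, and it differs from compound 3 by a group of 12 heavy atoms (10 carbon, 1 nitrogen, 1 oxygen; one six-membered aromatic ring of carbon only) in place of a group of 9 heavy atoms (7 carbon, 1 nitrogen, 1 oxygen; one six-membered aromatic ring of carbon only), on a saturated chain carbon, two bonds along the chain from an aromatic carbon. Going by the values given here, the one comparable step, no change at the digits printed from compound 2 to compound 3 (within the scatter), also moved the chain length and a ring substituent and left the value where it was. Compound 1, which carries the same methylphenyl amide as compound 4 but a chlorine on the shared core, gives a number only modestly above compound 2. Little movement is therefore expected: for compound 4 the estimated value is 20000 nM, within 8000 nM to 50000 nM, a step of a 1.3-fold higher number from compound 3 to compound 4 (0.11 log units; within the scatter).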

Compound 4, half-maximal inhibitory concentration: 15600 nM
The estimate for compound 4 lay 1.3-fold (0.11 log units) above the measured number; measured number inside the range.
By their numbers in this assay, from the lowest: compounds 2, 3 and 4 (each within the scatter of the next); then compound 1.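

In this assay, putting the 12-heavy-atom group in place of phenylcarbamoyl on the saturated chain carbon gives no change at the digits printed from compound 3 to compound 4 (within the scatter), so this larger change does not shift the reading. Methyl in place of fluoro on an aromatic carbon likewise gives no change at the digits printed from compound 2 to compound 4 (within the scatter). Hydrogen in place of chloro on an aromatic carbon gives a 2.1-fold lower number from compound 1 to compound 4 (0.32 log units; beyond the scatter), the only new step beyond the scatter, which points to the chlorine site rather than the chain as the place where the number moved.

No supporting data explain these results. Still open, going by these compounds, is whether a carboxylic acid or an amine in place of phenylcarbamoyl, or a longer chain, would move the number.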